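Shifting a methyl on the sulfonyl ring of compound 3

A few compounds are considered here, and "the series" means these few. Any claim that something is new, unique, unknown or untested is made for them only; others in the source may bear on it.

This small series shares one core, shown in compound 1 `O=C(Nc1cccc(/C=C/C(=O)c2nc3ccccc3[nH]2)c1)c1ccccc1`. It is tested in a functional assay on 143B cells (Homo sapiens) for antiproliferative activity, read by MTT assay, with a stated time of 48 h (on this read-out lower numbers stand for stronger inhibition and higher numbers for weaker inhibition), where compound 1 gives 8340 nM. Compound 2 `Cc1cccc(C(=O)Nc2cccc(/C=C/C(=O)c3nc4ccccc4[nH]3)c2)c1` carries a methyl on the benzoyl ring; in this assay compound 2 gives 4880 nM, and a 1.7-fold lower number from compound 1 to compound 2 (0.23 log units; within the scatter). Compound 3 `Cc1ccccc1S(=O)(=O)Nc1cccc(/C=C/C(=O)c2nc3ccccc3[nH]2)c1` replaces the benzoyl with a (2-methylphenyl)sulfonyl on the same nitrogen; in this assay compound 3 gives 4060 nM. Compound 3 thus stands apart from compound 1, since a 2.1-fold lower number from compound 1 to compound 3 (0.31 log units; beyond the scatter), while it cannot be told from compound 2, because a 1.2-fold lower number from compound 2 to compound 3 (0.08 log units; within the scatter).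

Compound 4 `Cc1cccc(S(=O)(=O)Nc2cccc(/C=C/C(=O)c3nc4ccccc4[nH]3)c2)c1` is not yet measured. The change from compound 3 is 3-methylphenyl in place of 2-methylphenyl on a sulfonyl sulfur. Going by the values given here, no measured step moves a methyl around a ring on the sulfonyl side. The closest hints are the methyl added in the step from compound 1 to compound 2 and the swap of a 3-methylphenyl carbonyl for a 2-methylphenyl sulfonyl from compound 2 to compound 3, both within the scatter. The expectation is therefore a 1.0-fold lower number from compound 3 to compound 4 (0.01 log units; within the scatter), with no real shift in this assay. Compound 4 is estimated at 4000 nM, expected to lie between 2000 nM and 8000 nM.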

Compound 4, half-maximal inhibitory concentration: 791 nM
Compound 4: middle estimate off by 5.1-fold (0.70 log units), on the high side; the measured number lies below the stated range.
By their numbers in this assay, from the lowest: compound 4; then compounds 3, 2 and 1 (each within the scatter of the next, the first and the last beyond it).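

In this assay, the place of a single methyl on the sulfonyl ring turns out to matter: the two compounds have the same atoms, yet 3-methylphenyl in place of 2-methylphenyl on the sulfonyl sulfur gives a 5.1-fold lower number from compound 3 to compound 4 (0.71 log units; beyond the scatter). With the 3-methylphenyl kept, the link to the nitrogen also counts, since (3-methylphenyl)sulfonyl in place of (3-methylphenyl)carbonyl gives a 6.2-fold lower number from compound 2 to compound 4 (0.79 log units; beyond the scatter), and the full change from the benzoyl of the first compound gives an 11-fold lower number from compound 1 to compound 4 (1.02 log units; beyond the scatter), the largest step in this small set. Nothing available here explains why moving the methyl has such an effect.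

Going by these compounds, it remains open whether the methyl itself contributes to the lower number, as a plain phenyl on the sulfonyl sulfur would be needed to test that. On these data alone, it is also open how an ethyl, a methoxy or a chlorine in place of that methyl would compare, and so whether the step from compound 3 to compound 4 is special to the methyl or extends to other groups on the ring.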